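The source may hold more compounds than are shown below. What is called first, only, known or untested is meant among the compounds shown, and "the series" means these compounds.

Of the compounds shown here, two built on the same core have been tested in a functional assay on SH-SY5Y cells (Homo sapiens) for cytotoxicity, read by MTT assay, with a stated time of 72 h; on this read-out lower numbers stand for stronger inhibition and higher numbers for weaker inhibition. Compound 1, `O=C1c2c[n+]([O-])c3ccccc3c2C(=O)c2c1c1ccccc1n2Cc1cn([C@@H]2C[C@H](O)[C@@H](CO)O2)nn1`, gives 150 nM in this assay. Compound 2, `O=C1c2c[n+]([O-])c3ccccc3c2C(=O)c2c1c1ccccc1n2CCN1CCCC1`, gives 520 nM in this assay. Of these two numbers compound 2 holds the higher one; its nearest neighbour is compound 1, whose number lies lower by a gap wider than the usual scatter of repeated measurements. Among the measured compounds shown here, no two measured compounds differ in just one place, so no single structural step has yet been tied to a change in the read-out.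

Compound 3, `CN1CCN(CCCCCn2c3c(c4ccccc42)C(=O)c2c[n+]([O-])c4ccccc4c2C3=O)CC1`, has not been measured. For the measured compounds named here, it differs from compound 2 in one place: 3-(4-methylpiperazin-1-yl)propyl in place of pyrrolidin-1-yl on a saturated chain carbon, two bonds along the chain from an aromatic nitrogen Nothing among the measured compounds shows what such a change does here, so the direction of the step from compound 2 to compound 3 in this assay is open; a step of modest size, in either direction, seems the most reasonable expectation. Compound 3 is expected to give about 450 nM in this assay, with a likely range from 150 nM to 1500 nM. That estimate amounts to an expected step of a 1.2-fold lower number from compound 2 to compound 3 (0.06 log units; within the scatter).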

Compound 3, half-maximal inhibitory concentration: 830 nM
Compound 3: the middle estimate sits 1.8-fold (0.27 log units) below what was measured, and the stated range covers the measured number.
By their numbers in this assay, from the lowest: compound 1; then compounds 2 and 3 (each within the scatter of the next).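

In this assay the step at this place, on a saturated chain carbon, two bonds along the chain from an aromatic nitrogen, is a 1.6-fold higher number from compound 2 to compound 3 (0.20 log units; within the scatter) and so stays within the usual scatter of repeated measurements. Replacing pyrrolidin-1-yl by 3-(4-methylpiperazin-1-yl)propyl therefore gives no change that can be told apart from that scatter. Nothing available explains this outcome or links it to any property of either group.

This single step swaps the ring and lengthens the chain together, since it also reads as 2-(pyrrolidin-1-yl)ethyl to 5-(4-methylpiperazin-1-yl)pentyl, so the two changes cannot be separated; pyrrolidin-1-yl on a pentyl chain, or 4-methylpiperazin-1-yl on an ethyl chain, would pull them apart. Also open, going by these compounds, is whether a different end group on the chain, such as a morpholine ring or a carboxylic acid, would move the number beyond the scatter.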